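This account rests on a few compounds, and the source may have more. Where it says the series, first, only, none or still open, it means among the compounds named here.

Compound 1 `O=C(/C=C/c1ccc2c(c1)B(O)OC2)c1ccccc1` is the starting point. In an ADME assay on L929 cells (Mus musculus) for cytotoxicity, read by resazurin assay, with a stated time of 72 h (on this read-out lower numbers stand for stronger inhibition and higher numbers for weaker inhibition), compound 1 gives > 10 ug/mL, which is a limit of the assay rather than a number, so its exact position is not known. Two close relatives were measured beside it. Compound 2 `COc1ccccc1C(=O)/C=C/c1ccc2c(c1)B(O)OC2` gives 6.35 ug/mL in this assay. Compound 3 `O=C(/C=C/c1ccc2c(c1)B(O)OC2)c1ccccc1F` gives > 10 ug/mL in this assay, which is again a limit. The step of an at least 1.5-fold lower number from compound 1 to compound 2 (0.19 log units; that floor lies within the scatter) can therefore be read from one side only, and the step that the two limits leave unreadable from compound 1 to compound 3 cannot be read at all, because of the limit of > 10 ug/mL in this assay, at which 2 of the 3 values shown sit. The step of an at least 1.5-fold higher number from compound 2 to compound 3 (0.19 log units; that floor lies within the scatter) is likewise only a floor.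

Compound 4 `O=C(/C=C/c1ccc2c(c1)B(O)OC2)c1ccc(-c2ccccc2)cc1` differs from compound 1 in one place: phenyl in place of hydrogen on an aromatic carbon. For the measured compounds named here, none of the measured steps concerns a phenyl group, and the one readable step, from compound 1 to compound 2, sits inside the usual scatter even at its floor. The measured data thus give no ground for a step beyond the scatter in either direction, and the chance that the assay again returns only a limit is high.

Compound 4 is expected to give 10 ug/mL in this assay, within a range from 4 ug/mL to 30 ug/mL. That amounts to an expected step of a number no higher from compound 1 to compound 4 (the limit leaves the size open).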

Compound 4, half-maximal inhibitory concentration: > 10 ug/mL
Compound 4 ended at the assay's limit (the forecaster's own chance of this, stated with the estimate: 60%); the middle value sits exactly at the limit.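

Compound 4 adds no readable step, and its comparison with compound 1 cannot be sized, because both compounds stop at the same limit of the assay: the limit of > 10 ug/mL in this assay, at which 3 of the 4 values shown sit.

Left open is how far compound 1, compound 3 and compound 4 lie past that limit, and so what phenyl in place of hydrogen does to the number in this assay.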